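Amide series on the shared core: methoxy for chloro

The source may hold more compounds than are shown below. What is called first, only, known or untested is meant among the compounds shown, and "the series" means these compounds.

Working notes. Compound 1 `O=C(Nc1cccc(O)c1)c1nccc2ccccc12`, compound 2 `O=C(Nc1ccc(Cl)cc1)c1nccc2ccccc12` and compound 3 `COc1ccccc1NC(=O)C1NCCc2ccccc21` have all been run in a functional assay on NUGC-3 cells (Homo sapiens) for inhibition, read by sulforhodamine B assay, with a stated time of 48 h; a lower number here means a stronger inhibitor of growth, a higher number a weaker inhibitor of growth. In this assay compound 1 gives only a limit, > 10000 nM. Compound 2 likewise gives only a limit, > 10000 nM. Compound 3 also stops at a limit, > 10000 nM. For the measured compounds named here, compound 2 therefore stands where every value so far stands, at the limit of > 10000 nM in this assay, at which 3 of the 3 values shown sit; no measured step separates any two of these three compounds. Compound 4 `COc1ccc(NC(=O)c2nccc3ccccc23)cc1` has not yet been measured. Compared with compound 2 the change is methoxy in place of chloro on an aromatic carbon. Going by the values given here, with no measured step in the set, the step that the limit leaves unreadable from compound 2 to compound 4 is expected to be none beyond the scatter. Compound 4 is thus estimated at 12000 nM, spanning 4000 nM to 40000 nM.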

Compound 4, concentration for 50% growth inhibition: > 10000 nM
Compound 4: no number, only a limit (the forecaster's own chance of this, stated with the estimate: 75%); the middle value does not contradict the limit.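

For the compounds shown here, compound 2 and compound 4 both give only a limit, so no step between them can be read: the limit of > 10000 nM in this assay, at which 4 of the 4 values shown sit. The compounds shown leave open what methoxy in place of chloro does to growth inhibition; none of them gives a number.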